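The compounds below may be only part of what the source reports. "The series", "measured", "known", "first", "only" and "open" are said of these compounds alone.

Three compounds sharing one core have numbers in a functional assay on MDA-MB-231 cells (Homo sapiens) for antiproliferative activity, read by MTT assay, with a stated time of 48 h; a lower number here means a stronger inhibitor, a higher number a weaker inhibitor: compound 1 `C=CS(=O)(=O)N1CCN(c2ncnc3sc(-c4ccc(C(F)(F)F)cc4)cc23)CC1` gives 6410 nM, compound 2 `C=CS(=O)(=O)N1CCN(c2ncnc3sc(-c4cccc5ccccc45)cc23)CC1` gives 23700 nM and compound 3 `C=CS(=O)(=O)N1CCN(c2ncnc3sc(-c4ccc(F)nc4)cc23)CC1` gives 16000 nM. Compound 3 lies within the scatter of compound 2, as shown by a 1.5-fold lower number from compound 2 to compound 3 (0.17 log units; within the scatter), and its number is higher than that of compound 1, as shown by a 2.5-fold higher number from compound 1 to compound 3 (0.40 log units; beyond the scatter).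

The next change gives compound 4 `C=CS(=O)(=O)N1CCN(c2ncnc3sc(-c4cccs4)cc23)CC1`, with thiophen-2-yl in place of 6-fluoropyridin-3-yl on an aromatic carbon, next to the ring sulfur (thiophen-2-yl in place of 6-fluoropyridin-3-yl on an aromatic carbon).

All three measured steps are swaps at this same place. The largest, a 3.7-fold higher number from compound 1 to compound 2 (0.57 log units; beyond the scatter), is modest, as is a 2.5-fold higher number from compound 1 to compound 3 (0.40 log units; beyond the scatter), while a 1.5-fold lower number from compound 2 to compound 3 (0.17 log units; within the scatter) stays within the scatter. Among the measured compounds shown here, no measured compound carries a five-membered aromatic ring here, so the data do not set a direction. In this assay, a step no larger than modest is therefore expected, and most likely none beyond the scatter, given the size of a 3.7-fold higher number from compound 1 to compound 2 (0.57 log units; beyond the scatter). The estimate amounts to a 1.2-fold lower number from compound 3 to compound 4 (0.09 log units; within the scatter), an expected step within the scatter. For compound 4 the estimated value is 13000 nM, with an expected range of 5500 nM to 30000 nM.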

Compound 4, half-maximal inhibitory concentration: 34100 nM
Compound 4: middle estimate off by 2.6-fold (0.42 log units), on the low side; measured number outside the range, above it.
By their numbers in this assay, from the lowest: compound 1; then compounds 3, 2 and 4 (each within the scatter of the next, the first and the last beyond it).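

Thiophen-2-yl is the first five-membered aromatic ring at this place, and it does not lower the number in this assay: a 2.1-fold higher number from compound 3 to compound 4 (0.33 log units; beyond the scatter) is modest and beyond the scatter, and a 5.3-fold higher number from compound 1 to compound 4 (0.73 log units; beyond the scatter) is the largest step yet seen at this position, though still modest. The gap to the fused aromatic group stays within the scatter (a 1.4-fold higher number from compound 2 to compound 4 (0.16 log units; within the scatter)), so thiophen-2-yl and naphthalen-1-yl are not separated here, while 4-(trifluoromethyl)phenyl in compound 1 remains the strongest of the four, with its steps to all the others beyond the scatter. Nothing shown gives a reason for these steps at this position.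

The compounds shown leave open how thiophen-3-yl would read at this place, which would show whether the attachment point of the five-membered ring matters in this assay. Also open, going by these compounds, is whether a phenyl ring carrying an amine or a carboxylic acid in place of the trifluoromethyl group, or a longer chain on that ring, would keep the number of compound 1 or move it in either direction.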